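A few compounds are considered here, and "the series" means these few. Any claim that something is new, unique, unknown or untested is made for them only; others in the source may bear on it.

Two compounds share a core that ends in an amine bearing a benzylic group. Compound 1 `O=S(=O)(NCCCCNCc1ccc(Br)cc1)c1cc(C(F)(F)F)cc(C(F)(F)F)c1` carries a 4-bromobenzyl group on that amine, while compound 2 `O=S(=O)(NCCCNCC1COc2ccccc2O1)c1cc(C(F)(F)F)cc(C(F)(F)F)c1` carries a (2,3-dihydro-1,4-benzodioxin-2-yl)methyl group. In a functional assay on Capan-2 cells (Homo sapiens) for inhibition, read by MTT assay, with a stated time of 72 h (on this read-out higher numbers stand for weaker inhibition of growth and lower numbers for stronger inhibition of growth), compound 1 gives 1900 nM, and in this assay compound 2 gives 2500 nM. On these two numbers compound 2 stands nearest to compound 1, and the gap between them lies within the usual scatter of repeated measurements, so neither can be called the stronger inhibitor of growth.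

Compound 3 `O=S(=O)(NCCCNCc1ccc(Br)cc1)c1cc(C(F)(F)F)cc(C(F)(F)F)c1` differs from compound 2 by 4-bromophenyl in place of 2,3-dihydro-1,4-benzodioxin-2-yl on a saturated chain carbon bound to an amine nitrogen. Compound 3 also differs from compound 1 only in the length of the chain between the shared core and the amine. Among the measured compounds shown here, no pair of measured compounds isolates either change, so no measured step shows what it does. Both measured compounds agree within the scatter, so the step in this assay from compound 2 to compound 3 is expected to be small, a 1.3-fold lower number from compound 2 to compound 3 (0.10 log units; within the scatter), with no clear direction. Compound 3 is therefore estimated at 2000 nM, within a range from 900 nM to 4500 nM.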

Compound 3, concentration for 50% growth inhibition: 2000 nM
Compound 3: middle estimate and measured number agree at the digits printed; the range from low to high includes it.
By their numbers in this assay, from the lowest: compounds 1, 3 and 2 (each within the scatter of the next).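

Compound 3 links the two earlier compounds, so each change can now be read on its own. In this assay, 4-bromophenyl in place of 2,3-dihydro-1,4-benzodioxin-2-yl on a saturated chain carbon bound to an amine nitrogen gives a 1.3-fold lower number from compound 2 to compound 3 (0.10 log units; within the scatter), so with this chain the 4-bromobenzyl and (2,3-dihydro-1,4-benzodioxin-2-yl)methyl groups cannot be told apart on this read-out. The chain change gives a 1.1-fold higher number from compound 1 to compound 3 (0.02 log units; within the scatter), so with 4-bromobenzyl on the amine, the chain lengths of these two compounds cannot be told apart either, and no evidence is at hand to explain why either change leaves the number within the scatter.

On these data alone, it remains open whether a plain benzyl group, a 4-chlorobenzyl group or a group bearing a carboxylic acid on the same amine would move the number beyond the scatter. Also open, as far as these compounds go, is whether a chain longer than that of compound 1 would do so, and whether the chain and the group on the amine act independently, which would need the (2,3-dihydro-1,4-benzodioxin-2-yl)methyl group on the longer chain of compound 1.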